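Dithiolane versus open dithiol on two amide cores

A few compounds are considered here, and "the series" means these few. Any claim that something is new, unique, unknown or untested is made for them only; others in the source may bear on it.

Compound 1 `O=C(CCCCC1CCSS1)Nc1ccc(Cl)cn1` and compound 3 `O=C(CCCCC(S)CCS)Nc1ccc(Cl)cn1` share one core; compound 2 `O=C(CCCCC1CCSS1)Nc1cccc2ccccc12` and compound 4 `O=C(CCCCC(S)CCS)Nc1cccc2ccccc12` share another. The difference between the two cores is not broken down here. All compounds are judged in a functional assay on KB cells (Homo sapiens) for inhibition, read by MTT assay, with a stated time of 24 h, tested at 100 ug/mL; a higher number here means more inhibition of growth at the concentration tested, a lower number less inhibition of growth.

In this assay compound 1 gives 74.5% and compound 3 gives 76.6%. The step of a number 2.1 percentage points higher from compound 1 to compound 3 (within the scatter) is the change (a group of 5 heavy atoms (3 carbon, 2 sulfur; no ring) in place of a group of 5 heavy atoms (3 carbon, 2 sulfur; one five-membered non-aromatic ring with 2 hetero atoms), on a saturated chain carbon, four bonds along the chain from a carbonyl carbon). It lies within the scatter, so the open dithiol and the ring leave the growth inhibition of this core essentially where it was.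

In this assay compound 2 gives "not active" (no number reported), with no number given. Compound 4 carries the same kind of change relative to compound 2: a group of 5 heavy atoms (3 carbon, 2 sulfur; no ring) in place of a group of 5 heavy atoms (3 carbon, 2 sulfur; one five-membered non-aromatic ring with 2 hetero atoms), on a saturated chain carbon, four bonds along the chain from a carbonyl carbon. The "place" lines of the two changes match word for word, so the same change sits at the same distance from the carbonyl carbon on both cores.

Among the compounds with values here, the expectation for compound 4 rests on the one measured instance of the change, namely that compound 1 to compound 3 moved by a number 2.1 percentage points higher from compound 1 to compound 3 (within the scatter), a step within the scatter. Carrying that over, compound 4 is expected to stay close to compound 2, that is, to show little growth inhibition. The estimate for compound 4 in this assay is 15%, expected to fall between 0% and 45%, with a real chance that only an inactive result and no number is reported again.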

Compound 4, percent growth inhibition at one concentration: "not active" (no number reported)
Compound 4: no number reported; there is nothing to compare the estimate with.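

In this assay, within the data shown here, compound 2 and compound 4 both stand without a number, so no step between them can be read. Nothing shown here bears on this result. The compounds shown leave open whether replacing the ring with 1,3-disulfanylpropyl changes growth inhibition on the core of compound 2, where neither compound gives a number to compare.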